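From 3,4-Dichlorophenyl to 3,5-Dichlorophenyl in Compound 1

The source may report more compounds than this note shows. Statements on the series, on what has been measured and on what is new or still open speak of the compounds shown alone.

Compound 1 `COc1cc(/C=C/C(=O)c2cccc(NC(=O)c3ccc(Cl)c(Cl)c3)c2)ccc1O` gives the highest of the two numbers shown in a functional assay on U-87MG ATCC cells (Homo sapiens) for inhibition (on this read-out lower numbers stand for stronger inhibition and higher numbers for weaker inhibition), at 29.5 ug/mL. Within the data shown here, compound 2 `COc1cc(/C=C/C(=O)c2cccc(NC(=O)c3ccco3)c2)ccc1O` gives 6.65 ug/mL in this assay, and the only measured step, a 4.4-fold lower number from compound 1 to compound 2 (0.65 log units; beyond the scatter), concerns a different change on that carbonyl carbon. Compound 3 `COc1cc(/C=C/C(=O)c2cccc(NC(=O)c3cc(Cl)cc(Cl)c3)c2)ccc1O` differs from compound 1 in one place: 3,5-dichlorophenyl in place of 3,4-dichlorophenyl on a carbonyl carbon. Among the measured compounds shown here, no measured step bears on this rearrangement, so no step beyond the scatter is expected in this assay, which is the meaning of a 1.1-fold lower number from compound 1 to compound 3 (0.02 log units; within the scatter). Compound 3 is therefore estimated at 28 ug/mL, within a range from 9 ug/mL to 85 ug/mL.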

Compound 3, half-maximal inhibitory concentration: > 50 ug/mL
Compound 3 gave a limit, no number; the forecaster's own chance of this, stated with the estimate: 10%; at least 1.7-fold (0.25 log units) between middle value and limit.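

Compound 3 gives a limit, not a number: the limit of > 50 ug/mL in this assay, at which 1 of the 3 values shown sits. Moving from 3,4-dichlorophenyl to 3,5-dichlorophenyl on this carbonyl carbon gives an at least 1.6-fold higher number from compound 1 to compound 3 (0.22 log units; that floor lies within the scatter), so this rearrangement of the same atoms has a size known only as a floor, and whether it changes the read-out at all stays unsettled. The furan-2-yl group, by contrast, stands clearly apart from the new dichlorophenyl group, with an at least 7.5-fold higher number from compound 2 to compound 3 (0.87 log units; beyond the scatter).

The compounds shown leave open how far the true value of compound 3 lies past its limit. They also leave open how an unsubstituted phenyl or a thiophen-2-yl on this carbonyl carbon would read in this assay.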